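The source may hold more compounds than are shown below. What is called first, only, known or untested is meant among the compounds shown, and "the series" means these compounds.

Measured in a functional assay on KB cells (Homo sapiens) for cytotoxicity, read by sulforhodamine B assay; on this read-out lower numbers stand for stronger inhibition and higher numbers for weaker inhibition:
compound 1 `C=C1[C@@H](C/C=C2/C(=O)OC[C@H]2OC(C)=O)[C@]2(C)CC[C@@H](OC(C)=O)[C@@](C)(CO[Si](C)(C)C(C)(C)C)[C@H]2C[C@@H]1O` gives 9790 nM
compound 2 `C=C1[C@@H](OC(C)=O)C[C@@H]2[C@](C)(CO[Si](C)(C)C(C)(C)C)[C@H](OC(C)=O)CC[C@@]2(C)[C@@H]1C[C@@H](Nc1ccccc1F)C1=CCOC1=O` gives 4740 nM
compound 3 `C=C1CC[C@@H]2[C@](C)(CO[Si](C)(C)C(C)(C)C)[C@H](OC(C)=O)CC[C@@]2(C)[C@@H]1C/C=C1/C(=O)OC[C@H]1OC(C)=O` gives 5050 nM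

Compound 2 has the lowest number of the three. Its gap to compound 3 is within the scatter, so no order can be read between those two; its gap to compound 1 is beyond the scatter. For the measured compounds named here, the only measured step, a 1.9-fold lower number from compound 1 to compound 3 (0.29 log units; within the scatter), concerns the core and lies within the scatter.

Compound 4 `C=C1[C@@H](OC(C)=O)C[C@@H]2[C@](C)(CO[Si](C)(C)C(C)(C)C)[C@H](OC(C)=O)CC[C@@]2(C)[C@@H]1C[C@@H](Nc1ccc(Br)cc1)C1=CCOC1=O` differs from compound 2 by 4-bromophenyl in place of 2-fluorophenyl on an amine nitrogen. Going by the values given here, no measured pair shows any swap on the amine nitrogen, so nothing bears on this change, and the one step in hand gives no direction either. For compound 4 the expected step, a 1.0-fold lower number from compound 2 to compound 4 (0.00 log units; within the scatter), should therefore stay within the scatter. Compound 4 is estimated at 4700 nM, range 2000 nM to 11000 nM.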

Compound 4, half-maximal inhibitory concentration: 5230 nM
Estimate against measurement, compound 4: 1.1-fold (0.05 log units) below; the measured number falls inside the stated range.
By their numbers in this assay, from the lowest: compounds 2, 3, 4 and 1 (each within the scatter of the next, the first and the last beyond it).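

In this assay, for the compounds shown here, the first swap on the amine nitrogen reads a 1.1-fold higher number from compound 2 to compound 4 (0.04 log units; within the scatter), so 2-fluorophenyl and 4-bromophenyl cannot be told apart at this position. This single step changes both the halogen and its place on the phenyl ring, so neither change can be read alone. No independent evidence bears on this result.

Still open, on these data alone, is whether unsubstituted phenyl or 2-bromophenyl would separate those two changes. Also open, as far as these compounds go, is whether cyclohexyl or methyl on this nitrogen would give a step beyond the scatter.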